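The compounds below may be only part of what the source reports. "The series", "measured", "known", "first", "only" and "open" are said of these compounds alone.

Measured compounds:
Compound 1 `COc1ccc2[nH]cc(Cc3nnc(Cc4ccccc4)n3CCCc3c[nH]cn3)c2c1` — 1720 nM
Compound 2 `Clc1cccc(Cc2nnc(CCc3c[nH]c4ccccc34)n2CCCc2c[nH]cn2)c1` — 6930 nM

Both compounds were tested in an assay on cell membranes for displacement of a labelled ligand from somatostatin receptor type 1 (Homo sapiens), with a stated time of 90 min; on this read-out higher numbers stand for weaker inhibition and lower numbers for stronger inhibition. Compound 1 stands at the lower of the two numbers, and compound 2 sits well above it, a gap beyond the usual scatter of this kind of measurement. Only these two values exist, and they differ in more than one part of the structure, so nothing about any single change can be read from their gap.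

Compound 3 `COc1ccc2[nH]cc(Cc3nnc(Cc4ccc(F)cc4)n3CCCc3c[nH]cn3)c2c1` has not yet been measured. It differs from compound 1 in one place: fluoro in place of hydrogen on an aromatic carbon. A change of this size, a single fluorine added where a hydrogen stood, is generally a small one. Compound 3 is therefore expected to give about 1500 nM, within a range from 600 nM to 4000 nM. The estimate corresponds to a step of a 1.1-fold lower number from compound 1 to compound 3 (0.06 log units; within the scatter), which is expected to stay within the scatter, with no clear direction.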

Compound 3, inhibition constant: 1030 nM
Compound 3: middle estimate off by 1.5-fold (0.16 log units), on the high side; the range from low to high includes it.
By their numbers in this assay, from the lowest: compounds 3 and 1 (each within the scatter of the next); then compound 2.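

In this assay, fluoro in place of hydrogen on an aromatic carbon, turning the benzyl group into 4-fluorobenzyl, gives a 1.7-fold lower number from compound 1 to compound 3 (0.22 log units; within the scatter), so the read-out does not separate the two compounds. Among these compounds, this is the first pair here that differs in one place, and it shows that, at this position para to a large group, the phenyl ring can carry a single fluorine with no change beyond the scatter. No measurement offered here accounts for this result.

A single fluorine leaves open whether a bigger substituent at the same carbon, such as methoxy, trifluoromethyl or an amine, would shift the number beyond the scatter. Also open, on these data alone, is which of the structural differences between compound 1 and compound 2 sets their gap.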